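A few compounds are considered here, and "the series" means these few. Any claim that something is new, unique, unknown or untested is made for them only; others in the source may bear on it.

In a functional assay on Huh-7 cells (Homo sapiens) for cytotoxicity, read by MTT assay, with a stated time of 3 days (a higher number here means that more compound is tolerated, a lower number that less compound is tolerated), compound 2 `OC[C@H]1O[C@@H](n2cnc3c(COc4ccccn4)ncnc32)[C@H](O)[C@@H]1O` gives > 250000 nM, which is a limit of the assay and not a number. Within the data shown here, compound 1 `CN(Cc1ncnc2c1ncn2[C@@H]1O[C@H](CO)[C@@H](O)[C@H]1O)c1ccccc1` gives 21000 nM, the only exact reading so far. Next in the series is compound 3 `CN(Cc1ccccc1)Cc1ncnc2c1ncn2[C@@H]1O[C@H](CO)[C@@H](O)[C@H]1O`, with this change: benzyl(methyl)amino in place of (pyridin-2-yl)oxy on a saturated chain carbon bound to an aromatic carbon. Among the measured compounds shown here, the one measured step that bears on it is an at least 11-fold higher number from compound 1 to compound 2 (1.07 log units; beyond the scatter), large and beyond the scatter, where (pyridin-2-yl)oxy took the place of methyl(phenyl)amino on the same saturated chain carbon. Compound 3 gives up that (pyridin-2-yl)oxy for benzyl(methyl)amino, which resembles the methyl(phenyl)amino of compound 1. Going by these compounds, on that measured step, a large move to a lower number is expected, though its exact size stays open. The estimated step is an at least 8.3-fold lower number from compound 2 to compound 3 (0.92 log units; beyond the scatter). For compound 3 the expected value is 30000 nM, with an estimated range of 9000 nM to 120000 nM.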

Compound 3, half-maximal cytotoxic concentration: 9000 nM
Compound 3: the middle estimate sits 3.3-fold (0.52 log units) above what was measured; the range from low to high includes it.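

On the saturated chain carbon bound to an aromatic carbon, a second amine now takes the place of (pyridin-2-yl)oxy, and in this assay the reading falls: an at least 27-fold lower number from compound 2 to compound 3 (1.44 log units; beyond the scatter). The low reading therefore does not belong to compound 1 alone, since compound 1 and compound 3, the two amines shown, both lie well under compound 2. The two amines still differ, with benzyl in place of phenyl on the amine nitrogen giving a modest step: a 2.3-fold lower number from compound 1 to compound 3 (0.37 log units; beyond the scatter).

Going by these compounds, compound 2 stands at a limit of the assay and not at a number, so the full size of its steps stays open: the limit of > 250000 nM in this assay, at which 1 of the 3 values shown sits. Also open is whether a phenoxy group at this place would read like the amines or like compound 2, and how a phenethyl group on the amine nitrogen would read.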